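Configuration at the piperidin-3-yl amide: compound 2 to compound 3

A few compounds are considered here, and "the series" means these few. Any claim that something is new, unique, unknown or untested is made for them only; others in the source may bear on it.

Measured so far in an ADME assay on microsomes from liver (Homo sapiens) for metabolic stability; on this read-out higher numbers stand for fast clearance and lower numbers for slow clearance.
- Compound 1 `Cc1ccc2[nH]c(C(=O)N[C@H]3CN(S(=O)(=O)c4ccccc4)C[C@@H]3C(=O)NC[C@H]3CCCN3C)cc2c1` gives 22 mL.min-1.g-1
- Compound 2 `Cc1ccc2[nH]c(C(=O)N[C@H]3CN(S(=O)(=O)c4ccccc4)C[C@@H]3C(=O)N[C@@H]3CCCNC3)cc2c1` gives 3 mL.min-1.g-1

Within the data shown here, of these two numbers, the lower belongs to compound 2 at 3 mL.min-1.g-1, and compound 1 is the only neighbour. Compound 3 `Cc1ccc2[nH]c(C(=O)N[C@H]3CN(S(=O)(=O)c4ccccc4)C[C@@H]3C(=O)N[C@H]3CCCNC3)cc2c1` has not yet been measured in this assay. Its relation to compound 2 is the two compounds have the same atoms and bonds and differ only in configuration as drawn: 1 of 3 stereo elements differ; a stereocentre at a saturated ring carbon is drawn R in compound 2 and S in compound 3. The two compounds have the same atoms and bonds, and a stereocentre at a saturated ring carbon is drawn R in compound 2 and S in compound 3.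

Among the measured compounds shown here, only one measured step bears on this change, and only loosely: a 7.3-fold lower number from compound 1 to compound 2 (0.87 log units; beyond the scatter). That step replaces the group at the same amide nitrogen, so it gives an upper guide rather than a direct precedent. For the measured compounds named here, no measured pair differs in configuration alone. A small rise in this assay is therefore expected, with no step beyond the scatter as the likeliest outcome. The expected step is a 1.7-fold higher number from compound 2 to compound 3 (0.22 log units; within the scatter). For compound 3 the estimated value is 5 mL.min-1.g-1, with an expected range from 2 mL.min-1.g-1 to 14 mL.min-1.g-1.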

Compound 3, intrinsic clearance in microsomes: < 3 mL.min-1.g-1
Compound 3 ended at the assay's limit; the forecaster's own chance of this, stated with the estimate: 10%; middle value at least 1.6-fold (0.22 log units) away from the limit.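

In this assay compound 3 gives < 3 mL.min-1.g-1, which is a limit of the assay and not a number. Replacing the (1-methylpyrrolidin-2-yl)methyl group with piperidin-3-yl in this configuration gives an at least 7.3-fold lower number from compound 1 to compound 3 (0.86 log units; beyond the scatter), so the low reading seen for compound 2 at this amide nitrogen is not confined to one drawn configuration of the piperidin-3-yl group: the fact that compounds 2 and 3 differ only in the configuration as drawn. Changing the configuration gives a number no higher from compound 2 to compound 3 (the limit leaves the size open), so this step cannot be read, and the size of any effect of the configuration remains hidden: the limit of < 3 mL.min-1.g-1 in this assay, at which 1 of the 3 values shown sits.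

On these data alone, compound 1 and the piperidin-3-yl amides differ at once in ring size, in the methyl on the ring nitrogen and in the methylene link to the amide nitrogen, and the share of each in the step remains open. A 1-methylpiperidin-3-yl amide or a pyrrolidin-3-yl amide would separate these features, while the order of compound 2 and compound 3 in this assay remains unresolved.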